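The compounds below may be only part of what the source reports. "The series", "measured", "known", "first", "only" and "open" are said of these compounds alone.

Of the compounds shown here, three sharing one core have been measured in an assay on membranes from CHO cells for displacement of a labelled ligand from adenosine receptor A1 (Homo sapiens), read by scintillation counting, with a stated time of 60 min, tested at 1 uM; on this read-out higher numbers stand for more inhibition at the one concentration tested (going by the name of the read-out) and lower numbers for less inhibition. Compound 1 `CCCOC(=O)C1=C(C)NC(=O)NC1c1ccsc1` gives 44%. Compound 2 `CC1=C(C(=O)C2CC2)C(c2ccsc2)NC(=O)N1` gives 2%, and compound 3 `CCNC(=O)C1=C(C)NC(=O)NC1c1ccsc1` gives 3%. Compound 3 stands second highest of the three numbers; its nearest neighbour is compound 2, with a number 1 percentage points higher from compound 2 to compound 3 (within the scatter), and the furthest is compound 1, with a number 41 percentage points lower from compound 1 to compound 3 (beyond the scatter). Compound 3 therefore sits among the low readings in this assay, with the clearly higher reading belonging to compound 1 alone.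

Compound 4 `CC1=C(C(=O)NC(C)C)C(c2ccsc2)NC(=O)N1` has not yet been measured. It differs from compound 3 in one place: methyl in place of hydrogen on a saturated chain carbon bound to an amide-type nitrogen and a saturated chain carbon. Within the data shown here, none of the measured steps touches the ethylamino group itself. The two large steps, a number 42 percentage points lower from compound 1 to compound 2 (beyond the scatter) and a number 41 percentage points lower from compound 1 to compound 3 (beyond the scatter), both replace the propoxy group of compound 1 on the carbonyl carbon, and the small step of a number 1 percentage points higher from compound 2 to compound 3 (within the scatter) swaps cyclopropyl for ethylamino. Nothing measured speaks directly to adding a methyl on the chain, so the expectation rests on the low readings of the two compounds whose carbonyl carbon carries something other than propoxy. Because compound 3 already gives only 3%, compound 4 is expected to stay low, with a number 1 percentage points higher from compound 3 to compound 4 (within the scatter) lying within the scatter. The estimate for compound 4 in this assay is 4%, with a range from 0% to 15%.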

Compound 4, a percentage reported as inhibition, at one concentration (the size of the read-out at that concentration, not a potency): 8%
The estimate for compound 4 lay 4 percentage points below the measured number, and the stated range covers the measured number.
By their numbers in this assay, from the lowest: compounds 2, 3 and 4 (each within the scatter of the next); then compound 1.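

In this assay, the step from ethylamino to isopropylamino is the only one shown that changes the ethylamino group itself, and it gives a number 5 percentage points higher from compound 3 to compound 4 (within the scatter), so this added methyl leaves the reading among the low readings. The isopropylamino group on the carbonyl carbon also reads level with cyclopropyl in that position, with a number 6 percentage points higher from compound 2 to compound 4 (within the scatter), but it stays well apart from propoxy, with a number 36 percentage points lower from compound 1 to compound 4 (beyond the scatter). Across these four compounds, cyclopropyl, ethylamino and isopropylamino on the carbonyl carbon all give low readings, and only compound 1, with propoxy, stands clearly higher; no measurement shown gives a reason for this gap.

The compounds shown leave open whether the higher reading depends on the propoxy chain in particular, since a shorter ethoxy group, a longer butoxy chain or a carboxylic acid on the same carbonyl carbon would be needed to test that. They also leave open whether a larger amide group, such as tert-butylamino or benzylamino, would stay as low as ethylamino and isopropylamino.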